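The source may report more compounds than this note shows. Statements on the series, on what has been measured and on what is new or still open speak of the compounds shown alone.

For the measured compounds named here, only two compounds have numbers so far. In a functional assay on Fem-X cells (Homo sapiens) for cytotoxicity (on this read-out lower numbers stand for stronger inhibition and higher numbers for weaker inhibition), compound 1 `CC1=CCC[C@H]2[C@](C)(CC3=CC(=O)C=CC3=O)[C@@H](C)CC[C@]12C` gives 23900 nM as its result, the lower of the two and so the stronger inhibition. Compound 2 `CC1=CCC[C@H]2[C@](C)(CC3=CC(=O)C4=C(SCCS4)C3=O)[C@@H](C)CC[C@]12C` gives 75000 nM on the same read-out, a gap larger than repeat measurements would normally produce.

The next compound to test is compound 3 `CC1=CCC[C@H]2[C@](C)(CC3=CC(=O)C(Sc4ccccc4)=CC3=O)[C@@H](C)CC[C@]12C`, which is compound 1 with a single change: phenylsulfanyl in place of hydrogen on a double-bonded ring carbon, counted as phenylsulfanyl in place of hydrogen on a double-bonded ring carbon in the structure. Going by the values given here, no measured pair of compounds differs in just one place, so nothing shows directly what such a change does, and any expectation is loose. Among the compounds with values here, compound 2 at 75000 nM shows only that a compound built on the same core can score worse than compound 1, and its change is not the one made here.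

A small shift toward a lower number is expected in this assay, possibly no larger than the scatter. This estimate amounts to a 1.7-fold lower number from compound 1 to compound 3 (0.23 log units; within the scatter) in size. For compound 3 the expected value is 14000 nM with an estimated range from 3500 nM to 45000 nM overall.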

Compound 3, half-maximal inhibitory concentration: 42500 nM
Estimate against measurement, compound 3: 3.0-fold (0.48 log units) below; the measured number falls inside the stated range.
By their numbers in this assay, from the lowest: compounds 1, 3 and 2 (each within the scatter of the next, the first and the last beyond it).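

In this assay, phenylsulfanyl in place of hydrogen on a double-bonded ring carbon gives a 1.8-fold higher number from compound 1 to compound 3 (0.25 log units; within the scatter). For the compounds shown here, this is the first comparison of two compounds that differ in just one place, and it shows that compound 1 and compound 3 cannot be told apart on this read-out, even though the entering group brings a six-membered aromatic ring of carbon only, joined through sulfur, where there was only a hydrogen atom. Nothing available explains this result, whether in terms of how the group acts or how the compounds work in the cells.

From the compounds shown here alone, it remains open whether other groups on the same ring carbon, such as an amine, a carboxylic acid or a longer chain like octylsulfanyl, would also read the same as hydrogen, or would move the number beyond the scatter in either direction. A single step at a single position on a single read-out sets no pattern, so it cannot yet be said whether this position generally accepts new groups or whether phenylsulfanyl is a special case.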